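This account rests on a few compounds, and the source may have more. Where it says the series, first, only, none or still open, it means among the compounds named here.

Compound 1, `CC1=C(/C=C/C(C)=C/C=C/C(C)=C\C(=O)Nc2ccc(F)cc2)C(C)(C)CCC1n1ccnc1`, is the amide with a 4-fluorophenyl group on the nitrogen. In a functional assay on PC-3 cells (Homo sapiens) for inhibition, read by MTT assay (on this read-out higher numbers stand for weaker inhibition of growth and lower numbers for stronger inhibition of growth), compound 1 gives 30200 nM, the highest of the three numbers seen so far. Compound 2, `CC1=C(/C=C/C(C)=C/C=C/C(C)=C\C(=O)Nc2ccccc2)C(C)(C)CCC1n1ccnc1`, carries a plain phenyl and gives 8910 nM in this assay; the step of a 3.4-fold lower number from compound 1 to compound 2 (0.53 log units; beyond the scatter) is the only one among these three that lies beyond the scatter. Compound 3, `CC1=C(/C=C/C(C)=C/C=C/C(C)=C\C(=O)Nc2ccccc2O)C(C)(C)CCC1n1ccnc1`, has a 2-hydroxyphenyl and gives 15500 nM; the step of a 1.9-fold lower number from compound 1 to compound 3 (0.29 log units; within the scatter) and the step of a 1.7-fold higher number from compound 2 to compound 3 (0.24 log units; within the scatter) both stay within the scatter.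

Compound 4, `CC1=C(/C=C/C(C)=C/C=C/C(C)=C\C(=O)Nc2cccc(F)c2)C(C)(C)CCC1n1ccnc1`, differs from compound 1 only in the position of the fluorine: 3-fluorophenyl in place of 4-fluorophenyl on an amide-type nitrogen. Among the compounds with values here, no measured step moves a fluorine from one position to another, so the nearest guidance comes from compound 1 and compound 2, where taking the fluorine away altogether lowered the number by a 3.4-fold lower number from compound 1 to compound 2 (0.53 log units; beyond the scatter), and from compound 1 and compound 3, where a different substituent on the ring gave a 1.9-fold lower number from compound 1 to compound 3 (0.29 log units; within the scatter). Both point, if anywhere, toward a lower number than compound 1. The step of a 1.9-fold lower number from compound 1 to compound 4 (0.28 log units; within the scatter) is therefore expected to be small and downward, possibly inside the scatter. Compound 4 is expected to give about 16000 nM in this assay, within a range from 6000 nM to 40000 nM.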

Compound 4, concentration for 50% growth inhibition: 5620 nM
The estimate for compound 4 lay 2.8-fold (0.45 log units) above the measured number, outside the stated range (below it).
By their numbers in this assay, from the lowest: compounds 4, 2, 3 and 1 (each within the scatter of the next, the first and the last beyond it).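

In this assay, within the data shown here, this is the first pair in which the fluorine changes position while the atoms stay the same, and the step of a 5.4-fold lower number from compound 1 to compound 4 (0.73 log units; beyond the scatter) shows that its place on the ring matters. Set against the plain phenyl of compound 2, the two fluorophenyl groups part ways: the step of a 1.6-fold lower number from compound 2 to compound 4 (0.20 log units; within the scatter) stays within the scatter, whereas the step of a 3.4-fold lower number from compound 1 to compound 2 (0.53 log units; beyond the scatter) lies beyond it, so among these compounds only the 4-fluorophenyl group stands apart from phenyl. The 3-fluorophenyl group also separates from the 2-hydroxyphenyl group, with the step of a 2.8-fold lower number from compound 3 to compound 4 (0.44 log units; beyond the scatter) beyond the scatter, although the step of a 1.7-fold higher number from compound 2 to compound 3 (0.24 log units; within the scatter) left compound 2 and compound 3 within the scatter of each other.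

No measurement here accounts for this dependence on the fluorine's place. As far as these compounds go, it also remains open whether a chlorine, a methoxy group or an amine in the place of the fluorine in 3-fluorophenyl would give a number like that of compound 4, or whether a second fluorine on the same ring would change it.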